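The compounds below may be only part of what the source reports. "The series", "measured", "known", "first", "only" and "open" are said of these compounds alone.

In a functional assay on HGC-27 cells (Homo sapiens) for antiproliferative activity, read by MTT assay, with stated times of 72 h and 4 h (a higher number here means a weaker inhibitor, a lower number a stronger inhibitor), the measured compounds are:
Compound 1 `COc1ncc(-c2cc3c(N4CCCC4)ncnc3s2)cc1NS(=O)(=O)c1ccc(F)cc1F`: 2300 nM
Compound 2 `COc1ncc(-c2cc3c(N4CCN(C)CC4)ncnc3s2)cc1NS(=O)(=O)c1ccc(F)cc1F`: 560 nM

Compound 2 has the lower of the two numbers. Compound 3 `COc1ncc(-c2cc3c(N4CCN(C)C(=O)C4)ncnc3s2)cc1NS(=O)(=O)c1ccc(F)cc1F` carries 4-methyl-3-oxopiperazin-1-yl in place of 4-methylpiperazin-1-yl on an aromatic carbon. For the measured compounds named here, the only measured step that bears on this change is a 4.1-fold lower number from compound 1 to compound 2 (0.61 log units; beyond the scatter), made at the same aromatic carbon. A step of similar or smaller size is therefore expected in this assay, probably towards a higher number, though one step cannot settle the direction. The expected change is a 2.0-fold higher number from compound 2 to compound 3 (0.29 log units; within the scatter). Compound 3 is estimated at 1100 nM, with an expected range of 350 nM to 3500 nM.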

Compound 3, half-maximal inhibitory concentration: 920 nM
The estimate for compound 3 lay 1.2-fold (0.08 log units) above the measured number; measured number inside the range.
By their numbers in this assay, from the lowest: compounds 2 and 3 (each within the scatter of the next); then compound 1.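

In this assay the 4-methyl-3-oxopiperazin-1-yl group on this aromatic carbon cannot be told apart from 4-methylpiperazin-1-yl (a 1.6-fold higher number from compound 2 to compound 3 (0.22 log units; within the scatter)), so adding the carbonyl to the ring leaves the number within the scatter. Compound 3 also keeps a clear margin over the pyrrolidin-1-yl compound (a 2.5-fold lower number from compound 1 to compound 3 (0.40 log units; beyond the scatter)), and thus both six-membered rings with 2 hetero atoms stand apart from it. Nothing measured here explains these results. On these data alone, whether morpholin-4-yl or an open-chain dimethylamino group would sit with compounds 2 and 3 or with compound 1 remains open.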